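Swapping fluoro for amino on a 5-HT7 binder

The compounds below may be only part of what the source reports. "The series", "measured", "known", "first", "only" and "open" are said of these compounds alone.

Measured compounds:
- compound 1, `CC1CN(CCn2ccc3ccc(Br)cc32)CC(C)N1`, gives 26%
- compound 2, `Brc1ccc2ccn(CCN3CCN(C4CCCCC4)CC3)c2c1`, gives 36%
- compound 3, `CN1CCCN(CCn2ccc3ccc(F)cc32)CC1`, gives 60%

All three were tested in an assay on HEK293 cells for binding affinity to 5-hydroxytryptamine receptor 7 (Homo sapiens), read by radioligand binding, tested at 1 uM; a lower number here means less inhibition, a higher number more inhibition at the concentration tested (going by the name of the read-out). Compound 3 stands highest of the three numbers: its value lies clearly above that of compound 2, the nearest of the others, and further still above that of compound 1, the furthest, with both gaps beyond the usual scatter of repeated measurements. Going by the values given here, compound 3 therefore gives the highest number among the compounds measured so far.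

The next compound keeps the core of compound 3 and changes a single group. Compound 4, `CN1CCCN(CCn2ccc3ccc(N)cc32)CC1`, differs from compound 3 as follows: amino in place of fluoro on an aromatic carbon. Among the compounds with values here, no step between two measured compounds at this position is available, so there is nothing to calibrate against; the other two compounds differ from compound 3 in several places at once and cannot serve as a guide.

With that in mind, a modest change is expected, most likely a small decrease in inhibition that may or may not clear the scatter, so the step of a number 10 percentage points lower from compound 3 to compound 4 (within the scatter) is the expectation. Compound 4 is therefore estimated to give 50% in this assay, within a range from 25% to 75%.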

Compound 4, a percentage reported as inhibition, at one concentration (the size of the read-out at that concentration, not a potency): 0%
For compound 4 the middle estimate is 50 percentage points above the measured one; measured number below the stated range.
By their numbers in this assay, from the lowest: compound 4; then compounds 1 and 2 (each within the scatter of the next); then compound 3.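

Going by these compounds alone, this is the first single-place step in the set, and it shows that the aromatic carbon carrying fluoro in compound 3 is highly sensitive to what sits there. In this assay, within the data shown here, the swap to amino gives a number 60 percentage points lower from compound 3 to compound 4 (beyond the scatter) as the only change, although it replaces just one heavy atom with another. Nothing available here accounts for this loss of inhibition, so the structures record that amino adds a hydrogen-bond donor and a hydrogen-bond acceptor but do not tie the drop to either.

Among these compounds, with only this one step at the position, it remains open whether the loss is particular to amino or whether hydroxyl, methoxy or an acetamide on the same carbon would behave alike. Going by these compounds, it is also open whether the same swap would have as large an effect with the different amine side chains of compound 1 and compound 2, and a single-concentration read-out cannot say how far potency changes from compound 3 to compound 4.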